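A few compounds are considered here, and "the series" means these few. Any claim that something is new, unique, unknown or untested is made for them only; others in the source may bear on it.

Of the compounds shown here, three that share one core have been measured in a functional assay on MOLT-4 cells (Homo sapiens) for inhibition; a higher number here means a weaker inhibitor, a lower number a stronger inhibitor. Here compound 1 `O=C1O/C(=C\Cn2ccc(=O)[nH]c2=O)C(OCc2ccccc2)=C1OCc1ccccc1` gives 4800 nM, compound 2 `O=C1O/C(=C\Cn2cc(Cl)c(=O)[nH]c2=O)C(OCc2ccccc2)=C1OCc1ccccc1` gives 6100 nM, and compound 3 `O=C1O/C(=C\Cn2cnc3c(-n4cccc4)ncnc32)C(OCc2ccccc2)=C1OCc1ccccc1` gives 3900 nM. The gaps from compound 1 to each of the other two lie within the usual scatter of repeated measurements, so these numbers do not rank it against them.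

The unmeasured compound 4 `O=C1O/C(=C\Cn2cc(F)c(=O)[nH]c2=O)C(OCc2ccccc2)=C1OCc1ccccc1` differs from compound 1 in one place: fluoro in place of hydrogen on an aromatic carbon.

Among the compounds with values here, one measured step bears on this change, chloro in place of hydrogen on that same aromatic carbon, a 1.3-fold higher number from compound 1 to compound 2 (0.10 log units; within the scatter). Within the data shown here, that step lies within the scatter, and it is the only such comparison available. A single step is thin evidence, but it gives no ground to expect a real shift, so no step beyond the scatter is expected in this assay, and no direction can be named. The expected step is a 1.0-fold higher number from compound 1 to compound 4 (0.02 log units; within the scatter). For compound 4 the estimated value is 5000 nM, with an expected range from 2300 nM to 10000 nM.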

Compound 4, half-maximal inhibitory concentration: 10900 nM
Compound 4: the middle estimate sits 2.2-fold (0.34 log units) below what was measured; the whole stated range lies below it.
By their numbers in this assay, from the lowest: compounds 3, 1, 2 and 4 (each within the scatter of the next, the first and the last beyond it).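

In this assay this aromatic carbon turns out not to be indifferent to what it carries: fluoro in place of hydrogen gives a 2.3-fold higher number from compound 1 to compound 4 (0.36 log units; beyond the scatter) and so a modestly weaker inhibitor, whereas the chloro swap at the same carbon, a 1.3-fold higher number from compound 1 to compound 2 (0.10 log units; within the scatter), had stayed within the scatter. The two halogens still cannot be told apart, since the direct comparison, a 1.8-fold higher number from compound 2 to compound 4 (0.25 log units; within the scatter), also lies within the scatter, so the result shows a real difference between fluoro and hydrogen but none between fluoro and chloro. Nothing available here explains why one fluorine atom in place of hydrogen moves the number this far.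

With only hydrogen, chloro and fluoro shown at this carbon, it remains open whether a methyl group, an amine or a nitrile there would leave the number close to that of compound 1 or move it further in either direction. Going by these compounds, the fluoro step also rests on a single pair of compounds, so whether the same swap has a similar effect on a different core remains unknown.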